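A few compounds are considered here, and "the series" means these few. Any claim that something is new, unique, unknown or untested is made for them only; others in the source may bear on it.

Compound 1 `CC(C)(C)C#Cc1cn([C@@H]2O[C@H](CO)[C@@H](O)[C@@H]2O)c(=O)[nH]c1=O`: in an ADME assay on L1210/0 cells (Mus musculus) for cytotoxicity, with a stated time of 48 h (a higher number here means a weaker inhibitor, a lower number a stronger inhibitor), compound 1 gives only a limit, > 200000 nM.
Compound 2 `N#Cc1cn([C@H]2C[C@H](O)[C@@H](CO)O2)c(=O)[nH]c1=O`: in this assay compound 2 likewise gives only a limit, > 200000 nM.

Both measured compounds share the same core, and neither returns a number in this assay. Going by the values given here, compound 2 therefore stands exactly where compound 1 stands, namely at the limit of > 200000 nM in this assay, at which 2 of the 2 values shown sit, so no order between the two can be read from the data, and no measured step between them exists. The unmeasured compound 3 `C=CC#Cc1cn([C@H]2C[C@H](O)[C@@H](CO)O2)c(=O)[nH]c1=O` differs from compound 2 by a group of 4 heavy atoms (4 carbon; no ring) in place of a group of 2 heavy atoms (1 carbon, 1 nitrogen; no ring), on an aromatic carbon. Among the compounds with values here, there is no measured step with which this change can be compared, and nothing in the two limits points toward a stronger inhibitor. The step from compound 2 to compound 3 in this assay is expected to be a step that the limit leaves unreadable from compound 2 to compound 3, essentially none beyond the scatter, with the outcome most likely once more a limit rather than a number. For compound 3 the estimate is 300000 nM, within 50000 nM to 2000000 nM.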

Compound 3, half-maximal inhibitory concentration: > 200000 nM
Compound 3 gave a limit, no number; the forecaster's own chance of this, stated with the estimate: 75%; the middle value does not contradict the limit.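

In this assay compound 3 gives only a limit, > 200000 nM. Compound 2 also gives only a limit, so no step between compound 2 and compound 3 can be read: the limit of > 200000 nM in this assay, at which 3 of the 3 values shown sit.

The compounds shown leave open whether any group on this aromatic carbon would give a measurable number in this assay.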